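The compounds below may be only part of what the source reports. "The series", "measured", "known", "first", "only" and "open" are said of these compounds alone.

Measured compounds:
- compound 1, `CC(C)(C)c1cc(/C=C/C(=O)NCCC2CCN(Cc3ccccc3)CC2)cc(C(C)(C)C)c1O`: 8500 nM
- compound 2, `CC(C)(C)c1cc(/C=C/C(=O)NCCC2CCN(Cc3ccc(F)cc3F)CC2)cc(C(C)(C)C)c1O`: 12500 nM

Both compounds were tested in an assay on isolated protein for inhibition of Amine oxidase [flavin-containing] B (Homo sapiens), read by fluorescence, with stated times of 15 min and 20 min; a lower number here means a stronger inhibitor, a higher number a weaker inhibitor. Compound 1 gives 8500 nM, and compound 2 gives 12500 nM. Compound 2 thus has the higher of the two numbers, but the step of a 1.5-fold higher number from compound 1 to compound 2 (0.17 log units; within the scatter) falls within the scatter, so the two values cannot be told apart. Compound 3, `CC(C)(C)c1cc(/C=C/C(=O)NCCC2CCN(Cc3ccccc3Cl)CC2)cc(C(C)(C)C)c1O`, has not yet been measured in this assay. It differs from compound 2 in one place: 2-chlorophenyl in place of 2,4-difluorophenyl on a saturated chain carbon bound to an amine nitrogen in a ring.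

Within the data shown here, the only measured step that bears on this change is the swap of the ring carried on the saturated chain carbon bound to the amine nitrogen in the ring, a 1.5-fold higher number from compound 1 to compound 2 (0.17 log units; within the scatter), which did not move the number beyond the scatter. Among the measured compounds shown here, no step shows a halogen placed as in compound 3, so the expectation rests on that one comparison. A step of a 1.3-fold lower number from compound 2 to compound 3 (0.10 log units; within the scatter) is expected, that is, no change beyond the scatter. Compound 3 is therefore estimated at 10000 nM, within a range from 4000 nM to 25000 nM.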

Compound 3, half-maximal inhibitory concentration: 9800 nM
For compound 3 the middle estimate is 1.0-fold (0.01 log units) above the measured one; the measured number falls inside the stated range.
By their numbers in this assay, from the lowest: compounds 1, 3 and 2 (each within the scatter of the next).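

Compound 3 adds a third aromatic group at this place, on a saturated chain carbon bound to an amine nitrogen in a ring, and in this assay it again leaves the number within the scatter. Replacing 2,4-difluorophenyl with 2-chlorophenyl gives a 1.3-fold lower number from compound 2 to compound 3 (0.11 log units; within the scatter), while adding chloro in place of hydrogen on an aromatic carbon gives a 1.2-fold higher number from compound 1 to compound 3 (0.06 log units; within the scatter), so the phenyl, 2,4-difluorophenyl and 2-chlorophenyl compounds cannot be told apart, and none of the three goes against this. Among these compounds, the first step also changes the halogen and the number of halogens together, yet neither that swap nor the single chloro shifts the reading beyond the scatter, and no available measurement accounts for this result.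

The compounds shown leave open whether any group at this place can move the number beyond the scatter, such as a methoxy group or a nitrile on the aromatic ring, a pyridine ring in place of the benzene ring, or a longer chain leading to it. They also leave open whether a change elsewhere in the shared core, such as at the amide, would matter more than these halogen swaps.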